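The source may report more compounds than this note shows. Statements on the series, on what has been measured and on what is new or still open speak of the compounds shown alone.

The series shares the core of compound 1 `CCCS(=O)(=O)N1CC=C(c2ccc3c(c2)CC(C2CCN(C(=O)OC(C)C)CC2)O3)CC1` with compound 2 `CCCS(=O)(=O)N1CC=C(c2ccc3c(c2)CC(C2CCN(c4ncc(C(F)(F)F)cn4)CC2)O3)CC1` and compound 3 `CCCS(=O)(=O)N1CC=C(c2ccc3c(c2)CC(C2CCN(c4ncc(C5CC5)cn4)CC2)O3)CC1`. In a functional assay on HEK293 cells with Glucose-dependent insulinotropic receptor (Homo sapiens) as the target, read by cAMP accumulation, with a stated time of 60 min (a lower number here means a smaller maximal response, a higher number a larger maximal response), compound 1 gives 61%, compound 2 gives 118% and compound 3 gives 85%, so compound 3 stands second highest of the three, with compound 1 nearest to it and compound 2 furthest. Compound 4 `CCCS(=O)(=O)N1CC=C(c2ccc3c(c2)CC(C2CCN(c4ccc(C(F)(F)F)cn4)CC2)O3)CC1` follows from compound 3 by 5-(trifluoromethyl)pyridin-2-yl in place of 5-cyclopropylpyrimidin-2-yl on an amine nitrogen in a ring. Going by the values given here, two measured steps bear on this: a number 33 percentage points lower from compound 2 to compound 3 (beyond the scatter), and a number 57 percentage points higher from compound 1 to compound 2 (beyond the scatter). Among the compounds with values here, no measured step separates 5-(trifluoromethyl)pyridin-2-yl from 5-(trifluoromethyl)pyrimidin-2-yl, so the expectation rests on the trifluoromethyl for cyclopropyl exchange alone. A rise beyond the scatter is therefore expected for compound 4, a number 20 percentage points higher from compound 3 to compound 4 (beyond the scatter). Compound 4 is estimated at 105%, with a range of 85% to 125%.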

Compound 4, largest response reached (Emax), in percent of the reference or control that the assay uses: 99%
Compound 4: middle estimate off by 6 percentage points, on the high side; the measured number falls inside the stated range.
By their numbers in this assay, from the lowest: compound 1; then compound 3; then compound 4; then compound 2.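

At the amine nitrogen in a ring, the aromatic ring itself matters with trifluoromethyl held fixed: this assay shows a number 19 percentage points lower from compound 2 to compound 4 (beyond the scatter), on going from a six-membered aromatic ring with 2 hetero atoms to one with 1 hetero atom. The 5-(trifluoromethyl)pyridin-2-yl group still stays ahead of the other two groups, with a number 14 percentage points higher from compound 3 to compound 4 (beyond the scatter) and a number 38 percentage points higher from compound 1 to compound 4 (beyond the scatter). Nothing measured here accounts for these steps.

Open, as far as these compounds go, is whether a nitrile or an amine in place of trifluoromethyl on the aromatic carbon would keep the maximal response. Also open, from the compounds shown here alone, is how cyclopropyl behaves on the six-membered aromatic ring with 1 hetero atom.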